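Acetylphenyl Replacing Naphthyl on a Shared Core

The source may report more compounds than this note shows. Statements on the series, on what has been measured and on what is new or still open speak of the compounds shown alone.

Measured compounds:
Compound 1, `c1ccc(-c2cn3ccnc3c(-c3ccc4ncn(C5CCCCC5)c4c3)n2)cc1`, gives 23.8% in a functional assay on Hs-578T cells (Homo sapiens) for inhibition, read by sulforhodamine B assay, with a stated time of 48 h, tested at 10 uM; a lower number here means less inhibition, a higher number more inhibition at the concentration tested (going by the name of the read-out).
Compound 2, `O=Cc1ccc(-c2cn3ccnc3c(-c3ccc4ncn(C5CCCCC5)c4c3)n2)cc1`, gives 45.5% in this assay.
Compound 3, `c1ccc2c(-c3cn4ccnc4c(-c4ccc5ncn(C6CCCCC6)c5c4)n3)cccc2c1`, gives 3.62% in this assay.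

Compound 3 stands lowest of the three measured numbers. Its nearest neighbour is compound 1, with a number 20.2 percentage points lower from compound 1 to compound 3 (beyond the scatter), and its furthest is compound 2, with a number 41.9 percentage points lower from compound 2 to compound 3 (beyond the scatter). Both gaps lie beyond the scatter, so compound 3 gives the lowest inhibition in this assay of the three.

Compound 4, `CC(=O)c1ccc(-c2cn3ccnc3c(-c3ccc4ncn(C5CCCCC5)c4c3)n2)cc1`, is not yet measured. It differs from compound 3 in one place: 4-acetylphenyl in place of naphthalen-1-yl on an aromatic carbon.

For the measured compounds named here, two measured steps bear on this change. The step from compound 2 to compound 3 replaced a 4-formylphenyl with a naphthalen-1-yl and lowered the read-out by a large amount; compound 4 carries a 4-acetylphenyl, the close relative of that formyl group, so the reverse of that step is the nearest guide. The step from compound 1 to compound 2 showed that adding a carbonyl-bearing group to the phenyl raised the read-out by a modest amount. A large rise in this assay is therefore expected for compound 4, with the step estimated as a number 36.4 percentage points higher from compound 3 to compound 4 (beyond the scatter). Compound 4 is expected to give about 40%, within a range from 20% to 60%.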

Compound 4, a percentage reported as inhibition, at one concentration (the size of the read-out at that concentration, not a potency): 6.34%
Compound 4: middle estimate off by 33.7 percentage points, on the high side; the measured number lies below the stated range.
By their numbers in this assay, from the lowest: compounds 3 and 4 (each within the scatter of the next); then compound 1; then compound 2.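

In this assay, one methyl on the carbonyl carbon separates two very different results: the change gives a number 39.2 percentage points lower from compound 2 to compound 4 (beyond the scatter), so the number for the 4-formylphenyl compound does not carry over to its close relative with 4-acetylphenyl. A carbonyl on this phenyl ring therefore does not by itself go with more inhibition, since formyl in place of hydrogen gives a number 21.7 percentage points higher from compound 1 to compound 2 (beyond the scatter), whereas acetyl in place of hydrogen gives a number 17.5 percentage points lower from compound 1 to compound 4 (beyond the scatter). Swapping naphthalen-1-yl for 4-acetylphenyl gives a number 2.7 percentage points higher from compound 3 to compound 4 (within the scatter), so at this position the assay does not separate a group with two aromatic rings and no hydrogen-bond acceptor from one with a single aromatic ring and a carbonyl.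

Nothing measured here explains why the formyl compound stands apart from the acetyl compound. Going by these compounds, it remains open whether formyl is a special case at this position or whether other one-carbon groups on the phenyl ring, such as hydroxymethyl or a carboxylic acid, would also give a number well above that of the plain phenyl compound.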